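The compounds below may be only part of what the source reports. "The series", "measured", "known", "first", "only" and "open" are said of these compounds alone.

Series notes. In a functional assay on A549 cells (Homo sapiens) for inhibition, read by MTT assay, with a stated time of 72 h (on this read-out lower numbers stand for stronger inhibition and higher numbers for weaker inhibition), compound 1 `O=c1cc(Cn2cc(CCO)nn2)c2ccc(O)cc2o1` gives 90300 nM. In this assay compound 2 `O=c1cc(Cn2cc(CCCO)nn2)c2ccc(O)cc2o1` gives 96200 nM. Compound 3 `O=c1cc(Cn2cc(CCCCO)nn2)c2ccc(O)cc2o1` returns only the limit of this assay, > 100000 nM, and so sits at the limit of > 100000 nM in this assay, at which 1 of the 3 values shown sits. The three values lie together: a 1.1-fold higher number from compound 1 to compound 2 (0.03 log units; within the scatter), an at least 1.1-fold higher number from compound 1 to compound 3 (0.04 log units; that floor lies within the scatter) and an at least 1.0-fold higher number from compound 2 to compound 3 (0.01 log units; that floor lies within the scatter) are each within the scatter, so extending the chain by hydroxymethyl or 2-hydroxyethyl moved nothing in this assay. Compound 4 `CCCCCCc1cn(Cc2cc(=O)oc3cc(O)ccc23)nn1` differs from compound 3 by ethyl in place of hydroxy on a saturated chain carbon, four bonds along the chain from an aromatic carbon. Among the measured compounds shown here, no measured step removes the hydroxy; the three steps seen vary chain length alone and all stayed within the scatter, so they give no direction for this change, only the observation that the series so far has stayed flat near the limit. The expected step in this assay is therefore none beyond the scatter, a number no higher from compound 3 to compound 4 (the limit leaves the size open). A fair chance remains that the assay again reports only a limit. Compound 4 is estimated at 100000 nM, with a range from 50000 nM to 200000 nM.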

Compound 4, half-maximal inhibitory concentration: 66200 nM
Estimate against measurement, compound 4: 1.5-fold (0.18 log units) above; measured number inside the range.
By their numbers in this assay, from the lowest: compounds 4, 1 and 2 (each within the scatter of the next). At a limit, above all of these: compound 3.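

In this assay, among the compounds shown here, the only exchange of the hydroxy for a chain without it gives an at least 1.5-fold lower number from compound 3 to compound 4 (0.17 log units; that floor lies within the scatter), and the pairs with the shorter alcohols give a 1.5-fold lower number from compound 2 to compound 4 (0.16 log units; within the scatter) and a 1.4-fold lower number from compound 1 to compound 4 (0.13 log units; within the scatter). For the compounds shown here, the hydroxy is therefore not required to hold the number: removing it from the chain, like varying the chain length, produced no step printed as beyond the scatter. The true size of the step from compound 3 remains open, since compound 3 has only a limit of the assay: the limit of > 100000 nM in this assay, at which 1 of the 4 values shown sits.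

Whether any group at the end of this chain can move the number beyond the scatter remains unsettled. An amine or a carboxylic acid in place of the hydroxy, or a longer chain, would test this.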